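The source may hold more compounds than are shown below. What is called first, only, known or untested is meant among the compounds shown, and "the series" means these compounds.

In an assay on isolated protein for binding affinity to Orexin/Hypocretin receptor type 1 (Homo sapiens) (a lower number here means a stronger inhibitor, a higher number a weaker inhibitor), compound 1 `Cc1cc(C)nc(N2C[C@H]3CN(C(=O)c4c(C)ccc5ccccc45)C[C@H]3C2)n1` gives 1800 nM, and compound 2 `COc1cccc(OC)c1C(=O)N1C[C@@H]2CN(c3nc4ccc(Cl)cc4s3)C[C@@H]2C1` gives 6850 nM. Compound 3 `COc1ccc(C(=O)N2C[C@@H]3CN(c4nc5ccc(F)cc5s4)C[C@@H]3C2)c(OC)c1` gives only a limit in this assay, > 10000 nM, so no number is known for it. It therefore sits at the limit of > 10000 nM in this assay, at which 1 of the 3 values shown sits. Compound 4 `COc1ccc(C(=O)N2C[C@@H]3CN(c4nc5ccc(Cl)cc5s4)C[C@@H]3C2)c(OC)c1` differs from compound 3 by chloro in place of fluoro on an aromatic carbon. Within the data shown here, no measured pair isolates this change, so the size of the step in this assay cannot be read off, and a change within the usual scatter is as plausible as a small gain. Compound 2, which also carries the chloro, gives a measurable value of 6850 nM, which suggests compound 4 may also fall inside the measurable range. Compound 4 is thus expected near 8000 nM, between 3000 nM and 25000 nM. The expected step from compound 3 is an at least 1.2-fold lower number from compound 3 to compound 4 (0.09 log units; that floor lies within the scatter).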

Compound 4, inhibition constant: 5300 nM
Beside the measured number, compound 4's estimate is 1.5-fold (0.18 log units) above it; measured number inside the range.
By their numbers in this assay, from the lowest: compound 1; then compounds 4 and 2 (each within the scatter of the next). At a limit, above all of these: compound 3.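

Chloro in place of fluoro on this aromatic carbon gives an at least 1.8-fold lower number from compound 3 to compound 4 (0.27 log units; that floor lies within the scatter), so the change now has a lower bound on its size, though not yet a size. Compound 3 gives no number, only a limit: the limit of > 10000 nM in this assay, at which 1 of the 4 values shown sits. With the chloro held fixed, the dimethoxyphenyl pattern on the carbonyl carbon gives a 1.3-fold lower number from compound 2 to compound 4 (0.11 log units; within the scatter), so 2,4-dimethoxyphenyl and 2,6-dimethoxyphenyl cannot be told apart here.

The compounds shown leave open how a bromo or an amine on this same aromatic carbon would compare with chloro.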